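Homologation at the piperidine of compound 3

A few compounds are considered here, and "the series" means these few. Any claim that something is new, unique, unknown or untested is made for them only; others in the source may bear on it.

For the measured compounds named here, compound 3 `CC1CCCN(C(=O)CN2CN(c3ccccc3)C3(CCN(C(=O)c4ccc(C(C)(C)C)cc4)CC3)C2=O)C1` gives 12000 nM in an assay on HEK293 cells for displacement of a labelled ligand from NPC1-like intracellular cholesterol transporter 1 (Homo sapiens) (a higher number here means a weaker inhibitor, a lower number a stronger inhibitor), the highest of the three numbers so far; compound 2 `CC1CCCN(C(=O)CN2CN(c3ccccc3)C3(CCN(C(=O)c4ccc(C5CCCCC5)cc4)CC3)C2=O)C1` gives 3600 nM and compound 1 `CC(C)(C)OC(=O)NCNC(=O)CN1CN(c2ccccc2)C2(CCN(C(=O)c3ccc(C4CCCCC4)cc3)CC2)C1=O` gives 1700 nM. The measured steps were a 2.1-fold higher number from compound 1 to compound 2 (0.33 log units; beyond the scatter) and a 3.3-fold higher number from compound 2 to compound 3 (0.52 log units; beyond the scatter). Compound 4 `CCC1CCCN(C(=O)CN2CN(c3ccccc3)C3(CCN(C(=O)c4ccc(C(C)(C)C)cc4)CC3)C2=O)C1` differs from compound 3 by methyl in place of hydrogen on a saturated chain carbon bound to a saturated ring carbon. Neither measured step concerns this position, so none bears directly on the change; both were modest, and going from methyl to ethyl on the 3-methylpiperidin-1-yl is a smaller alteration than either. No step beyond the scatter is expected in this assay in either direction. Compound 4 is therefore estimated at 12000 nM, with a range from 5000 nM to 30000 nM. The expected step is no change at the digits printed from compound 3 to compound 4 (within the scatter).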

Compound 4, half-maximal inhibitory concentration: 3900 nM
Estimate against measurement, compound 4: 3.1-fold (0.49 log units) above, and the stated range ends above it.
By their numbers in this assay, from the lowest: compound 1; then compounds 2 and 4 (each within the scatter of the next); then compound 3.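

In this assay, 3-ethylpiperidin-1-yl in place of 3-methylpiperidin-1-yl gives a 3.1-fold lower number from compound 3 to compound 4 (0.49 log units; beyond the scatter). This position therefore responds to one added methyl, and the step is rated modest, like the earlier exchanges of whole groups. Nothing available explains the step.

As far as these compounds go, whether a propyl or longer chain at this carbon lowers the number further, and how an amine or a carboxylic acid there would read, remains open. Also open, from the compounds shown here alone, is whether the ethyl step holds with cyclohexyl in place of tert-butyl on the aromatic carbon.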